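Hydrazone Aryl Swap and Expected Cytotoxicity in Monocytic Cells

The source may hold more compounds than are shown below. What is called first, only, known or untested is meant among the compounds shown, and "the series" means these compounds.

Measured compounds:
Compound 1, `COc1ccccc1-c1nnc(-c2ccc(C(=O)N/N=C/c3ccc(F)cc3)cc2)o1`: 427000 nM
Compound 2, `COc1ccccc1-c1nnc(-c2ccc(C(=O)N/N=C/c3ccc(O)c(O)c3)cc2)o1`: 100000 nM

Going by the values given here, in an ADME assay on THP-1 cells (Homo sapiens) for cytotoxicity (on this read-out lower numbers stand for stronger inhibition and higher numbers for weaker inhibition), compound 2 gives 100000 nM, the lowest of the two numbers measured; its only neighbour is compound 1, which in this assay gives 427000 nM. Among the compounds with values here, the single measured step, a 4.3-fold lower number from compound 1 to compound 2 (0.63 log units; beyond the scatter), came from replacing the aryl group on the carbon with a double bond to nitrogen, so the number moved modestly when that aryl group was exchanged.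

Compound 3, `COc1ccccc1-c1nnc(-c2ccc(C(=O)N/N=C/c3ccncc3)cc2)o1`, has not yet been measured. It differs from compound 2 by pyridin-4-yl in place of 3,4-dihydroxyphenyl on a carbon with a double bond to nitrogen. Within the data shown here, no measured step covers this exact exchange. Among the measured compounds shown here, the step from compound 1 to compound 2, a 4.3-fold lower number from compound 1 to compound 2 (0.63 log units; beyond the scatter), is the only guide and it shows only that a swap at this position can shift the number by a modest amount in either direction. Without a closer precedent, compound 3 is expected to sit between the two measured numbers, with a step of a 2.5-fold higher number from compound 2 to compound 3 (0.40 log units; beyond the scatter) back toward compound 1. Compound 3 is therefore estimated at 250000 nM, with a range from 80000 nM to 700000 nM.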

Compound 3, half-maximal inhibitory concentration: 173000 nM
Beside the measured number, compound 3's estimate is 1.4-fold (0.16 log units) above it; low and high end bracket the measured number.
By their numbers in this assay, from the lowest: compounds 2 and 3 (each within the scatter of the next); then compound 1.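

In this assay, the step at the carbon with a double bond to nitrogen is a 1.7-fold higher number from compound 2 to compound 3 (0.24 log units; within the scatter), so pyridin-4-yl and 3,4-dihydroxyphenyl cannot be told apart at this position. A group with no hydrogen-bond donors thus gives a number within the scatter of one with two, and among these three compounds the donor count does not track the read-out. The step of a 2.5-fold lower number from compound 1 to compound 3 (0.39 log units; beyond the scatter) shows that 4-fluorophenyl is separated from a second group as well, leaving compound 1 apart from both compound 2 and compound 3. Nothing shown bears on the reason for these steps.

As far as these compounds go, it remains open whether 4-fluorophenyl is an isolated case at this position or one end of a wider spread, which an unsubstituted phenyl, a phenyl carrying a carboxylic acid or a phenyl carrying a dimethylamino group could help to settle. From the compounds shown here alone, whether the same exchanges would give similar steps on a changed core also remains open, as all three compounds share one core.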